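A Methoxyethoxy Addition and Expected Cytotoxicity in Vero Cells

A few compounds are considered here, and "the series" means these few. Any claim that something is new, unique, unknown or untested is made for them only; others in the source may bear on it.

Compound 1 `Fc1ccc(-c2nn3ccc(NC4CCCC4)cc3c2-c2ccnc(NC3CCCC3)n2)cc1` is the only one of the three measured compounds that gives a number rather than a limit in an ADME assay on Vero cells (Chlorocebus sabaeus) for cytotoxicity; on this read-out higher numbers stand for lower toxicity in this test and lower numbers for higher toxicity in this test; in this assay compound 1 gives 18000 nM. Compound 2 `Fc1ccc(-c2nn3ccc(N4CCCC4)cc3c2-c2ccnc(NC3CCCC3)n2)cc1` reaches the limit of the assay, recorded as > 40000 nM in this assay. Compound 3 `c1cc(-c2c(-c3ccc(OCC4CC4)cc3)nn3ccc(NC4CCCC4)cc23)nc(NC2CCCC2)n1` likewise sits at the limit, recorded as > 40000 nM in this assay. The two steps from compound 1 are therefore open-ended: an at least 2.2-fold higher number from compound 1 to compound 2 (0.34 log units; beyond the scatter) and an at least 2.2-fold higher number from compound 1 to compound 3 (0.34 log units; beyond the scatter), both ending at the limit of > 40000 nM in this assay, at which 2 of the 3 values shown sit.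

Compound 4 `COCCOc1cc(NC2CCCC2)cc2c(-c3ccnc(NC4CCCC4)n3)c(-c3ccc(F)cc3)nn12` has not yet been measured. It differs from compound 1 by 2-methoxyethoxy in place of hydrogen on an aromatic carbon. Among the measured compounds shown here, neither measured step touches the same place or the same kind of group, so no direct precedent exists; what the two steps show is that single changes around the core of compound 1 have so far only moved the reading toward lower toxicity, with both runs ending at the limit. A modest rise in this assay, or none beyond the scatter, is therefore expected for compound 4, as a 1.4-fold higher number from compound 1 to compound 4 (0.14 log units; within the scatter). Compound 4 is estimated at 25000 nM in this assay, within a range from 10000 nM to 60000 nM.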

Compound 4, half-maximal cytotoxic concentration: 32500 nM
Estimate against measurement, compound 4: 1.3-fold (0.11 log units) below; measured number inside the range.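

With 2-methoxyethoxy in place of hydrogen on the aromatic carbon next to the ring nitrogen, this assay gives a 1.8-fold higher number from compound 1 to compound 4 (0.26 log units; within the scatter). Among the compounds shown here, the two earlier steps changed the cyclopentylamino group and the fluoro, whereas this one adds a chain of 5 heavy atoms to a carbon that carried only hydrogen, and it is the first change around the core of compound 1 that ends at a number rather than a limit. At this position, then, 2-methoxyethoxy leaves the reading indistinguishable from that of compound 1, so this one group gives no sign of higher toxicity in the test, and it cannot be credited with lower toxicity either.

On these data alone, whether the same position would read alike with a primary amine, a carboxylic acid or a longer ether chain stays open, since a single group at one site says nothing about the others. How far the two earlier changes truly reach also remains unknown, as their values are limits and not numbers: the limit of > 40000 nM in this assay, at which 2 of the 4 values shown sit.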